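The compounds below may be only part of what the source reports. "The series", "measured", "known", "first", "only" and "open" are said of these compounds alone.

The measured compounds in a physicochemical assay for solubility, at pH 6.8 (on this read-out higher numbers stand for higher solubility and lower numbers for lower solubility), are these:

compound 1, `Cc1c(COCCCCO)[nH]c2ccccc2c1=O`, >= 100000 nM
compound 2, `Cc1c(COc2cccc(OCC3CCOCC3)c2)[nH]c2ccc(Cl)cc2c1=O`, < 1000 nM
compound 3, `O=c1c(Cl)c(COc2cccc(OCC3CCOCC3)c2)[nH]c2ccccc12`, 2000 nM

Compound 2 does not give a number in this assay: its value is a limit of the assay, (the limit of < 1000 nM in this assay, at which 1 of the 3 values shown sits), so the true solubility of compound 2 is only known to sit at or past that boundary. Compound 1 likewise sits at a limit, (the limit of >= 100000 nM in this assay, at which 1 of the 3 values shown sits), at the opposite end of what the assay can report. Only compound 3 gives a plain number, and that number lies between the two limits.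

Compound 4, `Cc1c(COc2cccc(OCC3CCOCC3)c2)[nH]c2ccc(C(=O)O)cc2c1=O`, is the next compound and has not yet been measured. It differs from compound 2 in one place: carboxy in place of chloro on an aromatic carbon. Within the data shown here, no pair of measured compounds differs by this same change, so there is no measured step to read the size from, and the expectation rests on the three values alone.

For this assay a rise in solubility beyond the usual scatter is expected, a step of about an at least 30-fold higher number from compound 2 to compound 4 (1.47 log units; beyond the scatter). Compound 4 is therefore estimated at around 30000 nM, with a likely range from 3000 nM to 300000 nM.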

Compound 4, solubility: >= 100000 nM
Compound 4: no number, only a limit; the forecaster's own chance of this, stated with the estimate: 25%; at least 3.3-fold (0.52 log units) between middle value and limit.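

In this assay, among these compounds, replacing chloro with carboxy on this aromatic carbon, with the rest of the molecule unchanged, gives the first step in this set that can be read, an at least 100-fold higher number from compound 2 to compound 4 (2.00 log units; beyond the scatter). Compound 2 gives < 1000 nM, which is a limit of the assay: the limit of < 1000 nM in this assay, at which 1 of the 4 values shown sits. Compound 4 gives >= 100000 nM, which is also a limit of the assay, at the opposite end of its range: the limit of >= 100000 nM in this assay, at which 2 of the 4 values shown sit.

As far as these compounds go, with a limit at both ends, the true size of this step stays unknown, and so does how far compound 4 lies past its limit. The compounds shown also leave open whether an amine, an amide or a methyl ester on the same aromatic carbon would give a step like this one, and whether carboxy would do the same at another carbon of that ring.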